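Cytotoxicity notes on the step to compound 3

A few compounds are considered here, and "the series" means these few. Any claim that something is new, unique, unknown or untested is made for them only; others in the source may bear on it.

Going by the values given here, in an ADME assay on MDBK cells (Bos taurus) for cytotoxicity (on this read-out higher numbers stand for lower toxicity in this test and lower numbers for higher toxicity in this test), compound 2 `C(=C/c1ccccc1)\Cn1ccc2nc(-c3ccccc3)nc-2c1` gives 78000 nM, the only number so far. Compound 1 `Cc1ccccc1Cn1ccc2nc(-c3ccccc3)nc-2c1` reads > 100000 nM, which is a limit of the assay. Among the compounds with values here, the one measured step is an at least 1.2-fold lower number from compound 1 to compound 2 (0.10 log units; that floor lies within the scatter). Compound 3 `Clc1ccc(Cn2ccc3nc(-c4ccccc4)nc-3c2)s1` differs from compound 2 on a saturated chain carbon bound to an aromatic nitrogen: 5-chlorothiophen-2-yl in place of 2-phenylethenyl on a saturated chain carbon bound to an aromatic nitrogen. With so little measured, no step beyond the scatter is expected in this assay. The expected step is a 1.1-fold lower number from compound 2 to compound 3 (0.05 log units; within the scatter). For compound 3 the estimate is 70000 nM, with an expected range from 30000 nM to 100000 nM.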

Compound 3, half-maximal cytotoxic concentration: > 100000 nM
Compound 3: no number, only a limit; the forecaster's own chance of this, stated with the estimate: 35%; at least 1.4-fold (0.15 log units) between middle value and limit.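

In this assay, a five-membered aromatic ring with 1 hetero atom and a chlorine can take the place on the saturated chain carbon bound to an aromatic nitrogen, with an at least 1.2-fold higher number from compound 2 to compound 3 (0.10 log units; that floor lies within the scatter). Compound 3 gives > 100000 nM, a limit of the assay and not a number. A second group now reaches the top of the read-out, which caps what this position can show: the limit of > 100000 nM in this assay, at which 2 of the 3 values shown sit.

The step between compound 1 and compound 3 cannot be read. On these data alone, whether an amine or a carboxylic acid on this carbon would give a number clearly lower stays open.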